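Swapping an aromatic ring for a small branched chain

The source may report more compounds than this note shows. Statements on the series, on what has been measured and on what is new or still open speak of the compounds shown alone.

Of the compounds shown here, three sharing one core have been tested in an in vitro functional assay on cells for agonist activity at Bombesin receptor subtype-3 (Homo sapiens), read by luminescence and calcium flux; a higher number here means that more compound is needed for the effect, a lower number that less compound is needed. Compound 1 `O=C(O)c1ccccc1-c1ccc(CCc2ncc(CC3CCCCC3)[nH]2)cc1` gives 41 nM. Compound 2 `COc1ccc(Cc2cnc(CCc3ccc(-c4ccccc4C(=O)O)cc3)[nH]2)cc1` gives 5360 nM. Compound 3 `O=C(O)c1ccccc1-c1ccc(CCc2ncc(CCc3ccccc3)[nH]2)cc1` gives 1320 nM. Among these three numbers compound 3 stands second highest: a 32-fold higher number from compound 1 to compound 3 (1.51 log units; beyond the scatter), while a 4.1-fold lower number from compound 2 to compound 3 (0.61 log units; beyond the scatter).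

Compound 4 `CC(C)CCc1cnc(CCc2ccc(-c3ccccc3C(=O)O)cc2)[nH]1` has not yet been measured. It differs from compound 3 in one place: isopropyl in place of phenyl on a saturated chain carbon, two bonds along the chain from an aromatic carbon. The measured steps that bear on this change are those that trade a saturated group against an aromatic one at the same region of the molecule. There, a 130-fold higher number from compound 1 to compound 2 (2.12 log units; beyond the scatter) and a 32-fold higher number from compound 1 to compound 3 (1.51 log units; beyond the scatter); both show that replacing a saturated ring by an aromatic one raised the number strongly. Compound 4 moves the other way, from an aromatic ring to a saturated branched chain, though a smaller one than the saturated ring of compound 1.

On this basis a drop in this assay is expected, though not as far as the value of compound 1. The expected step is a 5.3-fold lower number from compound 3 to compound 4 (0.72 log units; beyond the scatter). Compound 4 is therefore estimated at 250 nM, within a range from 50 nM to 1500 nM.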

Compound 4, half-maximal effective concentration: 119 nM
Compound 4: the middle estimate sits 2.1-fold (0.32 log units) above what was measured; the measured number falls inside the stated range.
By their numbers in this assay, from the lowest: compound 1; then compound 4; then compound 3; then compound 2.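

The earlier compounds shown here showed a low number only with cyclohexyl, a saturated ring, but in this assay this result shows that a saturated group with no ring can also give a much lower number than an aromatic ring at this place: there is an 11-fold lower number from compound 3 to compound 4 (1.05 log units; beyond the scatter) for isopropyl in place of phenyl, and a 45-fold lower number from compound 2 to compound 4 (1.65 log units; beyond the scatter) for isobutyl in place of 4-methoxyphenyl. The ring of compound 1 still gives the lowest number of the four, since there is a 2.9-fold higher number from compound 1 to compound 4 (0.46 log units; beyond the scatter) on going from cyclohexyl to isobutyl, so dropping the aromatic ring accounts for more of the change than the remaining difference between the two saturated groups. Across these four compounds, both with and without a ring, the saturated end groups give lower numbers than the aromatic ones, and no compound here goes against that order.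

Nothing among the data given explains why these saturated groups give the lower numbers. As far as these compounds go, it also stays open how far the trend extends, for instance whether a cyclopentyl ring, a longer straight chain or an amine at the end of the chain would keep the number low.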